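The source may report more compounds than this note shows. Statements on the series, on what has been measured and on what is new or still open speak of the compounds shown alone.

Measured so far:
Compound 1 `CC1CCN(c2nc(Cl)nc3c2ncn3Cc2ccc(/C=C/C(=O)Nc3ccccc3N)cc2)CC1`: 32.2%
Compound 2 `Nc1ccccc1NC(=O)c1ccc(Cn2cnc3c(NCc4ccccc4)nc(Cl)nc32)cc1`: 62.8%
Compound 3 `Nc1ccccc1NC(=O)c1ccc(Cn2cnc3c(Nc4cccc(Cl)c4)nc(Cl)nc32)cc1`: 66.7%

In a functional assay on HepG2 cells (Homo sapiens) for antiproliferative activity, read by CCK-8 assay, with a stated time of 72 h, tested at 8 uM (a lower number here means a weaker effect, a higher number a stronger effect of the compound at the concentration tested), compound 2 gives the second highest of the three numbers. Its nearest neighbour is compound 3, reached by a number 3.9 percentage points higher from compound 2 to compound 3 (within the scatter), a change within the scatter; its furthest is compound 1, whose number lies beyond the scatter below it. Compound 4 `Nc1ccccc1NC(=O)/C=C/c1ccc(Cn2cnc3c(NCc4ccccc4)nc(Cl)nc32)cc1` is not yet measured. It differs from compound 2 in one place: 2-((2-aminophenyl)carbamoyl)ethenyl in place of (2-aminophenyl)carbamoyl on an aromatic carbon. For the measured compounds named here, no measured step shows this change on its own. Compound 1 carries the same 2-((2-aminophenyl)carbamoyl)ethenyl group, but differs from compound 4 in a second place as well, so its value only hints at a weaker effect. Compound 4 is therefore expected to show a number 12.8 percentage points lower from compound 2 to compound 4 (beyond the scatter), a small drop that may not exceed the scatter. The estimate for compound 4 is 50%, ranging from 30% to 70%.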

Compound 4, a percentage reported as inhibition, at one concentration (the size of the read-out at that concentration, not a potency): 37.7%
Compound 4: middle estimate off by 12.3 percentage points, on the high side; measured number inside the range.
By their numbers in this assay, from the lowest: compounds 1 and 4 (each within the scatter of the next); then compounds 2 and 3 (each within the scatter of the next).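

In this assay the change from (2-aminophenyl)carbamoyl to 2-((2-aminophenyl)carbamoyl)ethenyl, on an aromatic carbon para to a large group, can now be read alone: it gives a number 25.1 percentage points lower from compound 2 to compound 4 (beyond the scatter) with the rest of the molecule unchanged. With the ethenyl group kept, benzylamino in place of 4-methylpiperidin-1-yl gives a number 5.5 percentage points higher from compound 1 to compound 4 (within the scatter) and so no clear change at that other place. Nothing measured here gives a reason for the drop. Still open, from the compounds shown here alone, is how a saturated ethyl link or a longer chain would compare at this position, and whether a hydroxamic acid could take the place of the 2-aminophenyl amide.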